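The source may report more compounds than this note shows. Statements on the series, on what has been measured and on what is new or still open speak of the compounds shown alone.

Measured compounds in a functional assay on PC-3 cells (Homo sapiens) for cytotoxicity, read by MTT assay, with a stated time of 72 h; a lower number here means a stronger inhibitor of growth, a higher number a weaker inhibitor of growth:

Compound 1 `COc1ccc(OC(=O)Nc2ccc([Se]C#N)cc2)cc1` gives 44600 nM.
Compound 2 `CCCCOC(=O)Nc1ccc([Se]C#N)cc1` gives 40800 nM.
Compound 3 `CC(C)COC(=O)Nc1ccc([Se]C#N)cc1` gives 47300 nM.

All three share the same core and differ only in the group on the carbamate oxygen. Compound 1 sits among the other two: its number and those of compound 2 and compound 3 lie within the scatter of one another, so no order among them can be read. For the measured compounds named here, the single step between neighbours, a 1.2-fold higher number from compound 2 to compound 3 (0.06 log units; within the scatter), concerns the alkyl side of the series and is also within the scatter.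

Compound 4 `N#C[Se]c1ccc(NC(=O)Oc2ccc(F)cc2)cc1` differs from compound 1 by fluoro in place of methoxy on an aromatic carbon. Going by the values given here, no measured pair shows this change; the only measured step touches a different part of the molecule and stays within the scatter, and the three numbers so far are flat across quite different groups on the carbamate oxygen. The step of a 1.0-fold higher number from compound 1 to compound 4 (0.00 log units; within the scatter) is therefore expected to be none beyond the scatter. Compound 4 is expected at 45000 nM, within 20000 nM to 100000 nM.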

Compound 4, concentration for total growth inhibition: 40400 nM
The estimate for compound 4 lay 1.1-fold (0.05 log units) above the measured number, within the range that was stated.
By their numbers in this assay, from the lowest: compounds 4, 2, 1 and 3 (each within the scatter of the next).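

In this assay, the change from methoxy to fluoro on an aromatic carbon, para to a large group, gives a 1.1-fold lower number from compound 1 to compound 4 (0.04 log units; within the scatter). The earlier step concerned only the alkyl side of the carbamate oxygen, whereas this pair tests the aromatic ring there directly: exchanging methoxy for a single fluorine atom at this place produces no readable change in the growth-inhibition number. No independent measurement bears on why the number holds at this place.

Going by these compounds, it remains open whether an amine or a carboxylic acid at the same place would move the number beyond the scatter. On these data alone, it is equally open whether a longer chain on the carbamate oxygen, such as octyl, would do so, since all four compounds so far lie within the scatter of their neighbours.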